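The compounds below may be only part of what the source reports. "The series", "measured", "known", "first", "only" and "open" are said of these compounds alone.

Three compounds share one core, and all three have been tested in a functional assay on OVCAR-4 cells (Homo sapiens) for inhibition; on this read-out higher numbers stand for weaker inhibition of growth and lower numbers for stronger inhibition of growth. Compound 1 `O=C(/C=C/c1cccc(O)c1)c1cccc(-n2cc(-c3ccccc3)[nH]c2=O)c1` gives 5300 nM in this assay. For the measured compounds named here, compound 2 `O=C(/C=C/c1cccc(O)c1)c1cccc(-n2cc(-c3ccc(Cl)cc3)[nH]c2=O)c1` gives 2210 nM in this assay, the lowest of the three numbers; a 2.4-fold lower number from compound 1 to compound 2 (0.38 log units; beyond the scatter) came with the single change of chloro in place of hydrogen on an aromatic carbon. Compound 3 `COc1cc(/C=C/C(=O)c2cccc(-n3cc(-c4cc(OC)c(OC)c(OC)c4)[nH]c3=O)c2)cc(OC)c1OC` gives 3770 nM in this assay, a number within the scatter of compound 2, so no order between these two can be read.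

Compound 4 `COc1cc(/C=C/C(=O)c2cccc(-n3cc(-c4ccc(Cl)cc4)[nH]c3=O)c2)ccc1O` differs from compound 2 in one place: 4-hydroxy-3-methoxyphenyl in place of 3-hydroxyphenyl on a double-bonded chain carbon bound to a double-bonded chain carbon. Going by the values given here, no measured step changes that ring alone. The chloro step from compound 1 to compound 2 sits on the other ring and does not bear on this change. Compound 3 carries three methoxy groups on each of both rings, and its number lies near that of compound 1, which hints that substitution on this ring leaves the number roughly where it is. A step within the scatter is therefore expected, a 1.0-fold lower number from compound 2 to compound 4 (0.00 log units; within the scatter). Compound 4 is estimated at 2200 nM, with a range from 1000 nM to 5000 nM.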

Compound 4, concentration for 50% growth inhibition: 4640 nM
Estimate against measurement, compound 4: 2.1-fold (0.32 log units) below, within the range that was stated.
By their numbers in this assay, from the lowest: compounds 2, 3, 4 and 1 (each within the scatter of the next, the first and the last beyond it).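

In this assay, the ring on the double-bonded chain carbon proves able to move the number: putting 4-hydroxy-3-methoxyphenyl in place of 3-hydroxyphenyl gives a 2.1-fold higher number from compound 2 to compound 4 (0.32 log units; beyond the scatter), a modest step towards weaker inhibition of growth. This is the only step shown that changes this ring alone, so it adds a reading at a position that the chloro step on the other ring could not address. The evidence at hand offers no explanation for this step.

The names show two differences in this one change, a methoxy group gained and the hydroxy group at a different number, so 3-methoxyphenyl and 4-hydroxyphenyl at this place would be needed to tell them apart. On these data alone, how this ring would read with an amine or a carboxylic acid in place of the hydroxy group also remains open.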